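This account rests on a few compounds, and the source may have more. Where it says the series, first, only, none or still open, it means among the compounds named here.

Going by the values given here, in a functional assay on U-937 cells (Homo sapiens), read by cAMP accumulation (a higher number here means that more compound is needed for the effect, a lower number that less compound is needed), three compounds have numbers so far. Compound 1 `CCc1nn(C2CCCC2)c2c1CCN(c1ccccc1)C2=O` gives 70 nM, the lowest of the three and clearly apart from the others. Compound 2 `CCc1nn(-c2ccc(F)cc2)c2c1CCN(c1ccc(C)cc1)C2=O` gives 500 nM, and compound 3 `CCc1nn(-c2ccc(F)cc2)c2c1CCN(c1cccc(C)c1)C2=O` gives 780 nM.

Compound 4 `CCc1nn(C2CCCC2)c2c1CCN(c1cccnc1)C2=O` has not yet been measured. It keeps the core of compound 1 and changes one group: pyridin-3-yl in place of phenyl on an amide-type nitrogen in a ring. Phenyl is an aromatic ring of carbon only, whereas pyridin-3-yl is an aromatic ring with a hetero atom and a hydrogen-bond acceptor.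

Among the compounds with values here, only one measured step touches this place: a 1.6-fold higher number from compound 2 to compound 3 (0.19 log units; within the scatter), with 3-methylphenyl in place of 4-methylphenyl. That step stays within the scatter, but it only relocates a methyl group and offers weak guidance on a change to the ring itself. Compounds 2 and 3 also differ from compound 1 elsewhere, so their higher numbers cannot be pinned on this position. Within the data shown here, no measured pair shows this exact swap, so the forecast is uncertain. Since compound 1 already sits lowest, a higher number seems the likelier direction. The expected change is small, an estimated 2.1-fold higher number from compound 1 to compound 4 (0.33 log units; beyond the scatter). For compound 4 the estimated value is 150 nM, with an expected range of 40 nM to 600 nM.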

Compound 4, half-maximal effective concentration: 17 nM
Beside the measured number, compound 4's estimate is 8.8-fold (0.95 log units) above it, and the stated range ends above it.
By their numbers in this assay, from the lowest: compound 4; then compound 1; then compounds 2 and 3 (each within the scatter of the next).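

In this assay, pyridin-3-yl in place of phenyl on an amide-type nitrogen in a ring gives a 4.1-fold lower number from compound 1 to compound 4 (0.61 log units; beyond the scatter), a step beyond the scatter, with the size of the ring and its count of heavy atoms unchanged and one ring carbon exchanged for a nitrogen. Going by these compounds alone, the only earlier step at this place, a 1.6-fold higher number from compound 2 to compound 3 (0.19 log units; within the scatter), moved a methyl group around a phenyl ring and stayed within the scatter, so this is the first clear sign that the number in this assay responds to a change at this position, and that a change to the ring itself can lower it. No measurement at hand explains why this swap lowers the number.

The compounds shown leave open how other rings or substituents at this position would behave, such as a pyrimidine ring or a phenyl ring carrying an amine or a carboxylic acid. They also leave open whether the same swap would lower the number when the cyclopentyl group of compound 1 is replaced by the fluorophenyl group of compound 2.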